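The source may hold more compounds than are shown below. What is called first, only, known or untested is meant among the compounds shown, and "the series" means these compounds.

Measured so far in an assay on HEK293 cells for displacement of a labelled ligand from adenosine receptor A2b (Homo sapiens), with a stated time of 30 min; on this read-out higher numbers stand for weaker inhibition and lower numbers for stronger inhibition:
compound 1 `CCOC(=O)C1=C(C)NC(=S)NC1c1ccoc1`: 43.1 nM
compound 2 `CC1=C(C(=O)OC(C)C)C(c2ccoc2)NC(=S)N1`: 194 nM

Within the data shown here, compound 2 stands at the highest of the two numbers in this assay; the only neighbour is compound 1, and the one measured step, a 4.5-fold higher number from compound 1 to compound 2 (0.65 log units; beyond the scatter), concerns methyl in place of hydrogen on a saturated chain carbon bound to an oxygen next to a carbonyl group and a saturated chain carbon.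

Compound 3 `CC1=C(C(=O)OC(C)C)C(c2ccsc2)NC(=S)N1` differs from compound 2 by thiophen-3-yl in place of furan-3-yl on a saturated ring carbon — thiophen-3-yl in place of furan-3-yl on a saturated ring carbon. Among the measured compounds shown here, none of the measured steps bears on this change: the step from compound 1 to compound 2 alters the isopropoxycarbonyl group, not the five-membered aromatic ring, so there is no measured basis for a shift in either direction. The expectation for compound 3 in this assay is therefore a number close to that of compound 2, with no step beyond the scatter; the expected step is a 1.0-fold lower number from compound 2 to compound 3 (0.01 log units; within the scatter). Compound 3 is estimated at 190 nM, with a range from 80 nM to 450 nM.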

Compound 3, inhibition constant: 416 nM
Beside the measured number, compound 3's estimate is 2.2-fold (0.34 log units) below it, within the range that was stated.
By their numbers in this assay, from the lowest: compound 1; then compound 2; then compound 3.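

In this assay the group on the saturated ring carbon now proves able to move the number: with the isopropoxycarbonyl group held constant, thiophen-3-yl in place of furan-3-yl gives a 2.1-fold higher number from compound 2 to compound 3 (0.33 log units; beyond the scatter) in a step that is modest in size. Among these compounds, the earlier compounds varied only the ester side, so this is the first reading of the five-membered aromatic ring itself. The position responds even though the two groups match in heavy atoms, hydrogen-bond donors, hydrogen-bond acceptors and net charge as counted, and differ only in oxygen against sulfur as the hetero atom. Nothing at hand gives a measured basis for explaining this step.

As far as these compounds go, whether the same exchange gives a step of similar size and direction with the ethoxycarbonyl group of compound 1 remains open, since one pair cannot show whether the two places act independently. Also open, from the compounds shown here alone, is how a phenyl ring, a furan-2-yl group or a thiophen-2-yl group would read on the same saturated ring carbon, and so whether the hetero atom's identity or its place in the ring counts for more.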